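The source may hold more compounds than are shown below. What is called first, only, known or untested is meant among the compounds shown, and "the series" means these compounds.

Compound 1 `Fc1ccc(Nc2cc3[nH]c(-c4cccc(C(F)(F)F)c4)nc3cn2)nc1`: >= 50000 nM
Compound 2 `CN1CCN(c2ccc(Nc3cc4[nH]c(-c5cccc(C(F)(F)F)c5)nc4cn3)nc2)CC1`: < 5000 nM
Compound 3 `FC(F)(F)c1ccc(Nc2cc3[nH]c(C4CCCC4)nc3cn2)nc1`: 85000 nM

Among the compounds with values here, in a physicochemical assay for solubility, using the shake flask method, in simulated intestinal fluid, measured as kinetic solubility, with a stated time of 20 h, at pH 6.5 (a lower number here means a less soluble compound, a higher number a more soluble compound), compound 3 gives 85000 nM, the only exact number so far. For compound 1, >= 50000 nM is a limit. For compound 2, < 5000 nM is also a limit.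

Compound 4 `FC(F)(F)c1ccc(Nc2cc3[nH]c(C4CCOCC4)nc3cn2)nc1` carries oxan-4-yl in place of cyclopentyl on an aromatic carbon. Within the data shown here, the only measured step, an at least 10-fold lower number from compound 1 to compound 2 (1.00 log units; beyond the scatter), put 4-methylpiperazin-1-yl in place of fluoro, a different swap at a different place, so it is a poor guide here. Among the measured compounds shown here, no measured step tests this change directly. The expected 1.2-fold higher number from compound 3 to compound 4 (0.07 log units; within the scatter) is therefore small and within the scatter, with no firm direction. For compound 4 the estimated value is 100000 nM, with an expected range from 45000 nM to 200000 nM.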

Compound 4, solubility: 168000 nM
The estimate for compound 4 lay 1.7-fold (0.23 log units) below the measured number; the range from low to high includes it.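

In this assay, within the data shown here, oxan-4-yl in place of cyclopentyl gives a 2.0-fold higher number from compound 3 to compound 4 (0.30 log units; within the scatter) as the first step here between two exact numbers, and it sits at a different place from the earlier step. At this aromatic carbon between two ring nitrogen atoms, then, a six-membered ring with one oxygen stands in for a five-membered carbon ring with no change beyond the scatter. On these data alone, what remains open is whether a ring carrying an amine, or a carboxylic acid, at this place would move the number beyond the scatter. Nothing measured here gives a reason for this result.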